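Cyclopropyl for isopropyl on the 1,2,4-oxadiazol-3-yl group

A few compounds are considered here, and "the series" means these few. Any claim that something is new, unique, unknown or untested is made for them only; others in the source may bear on it.

Measured so far:
compound 1 `CCCN(CC[C@H]1CC[C@H](NC(=O)c2ccc(-n3cncn3)cc2)CC1)[C@H]1CCc2nc(N)sc2C1`: 2.4 nM
compound 2 `CCCN(CC[C@H]1CC[C@H](NC(=O)c2ccc(-c3noc(C(C)C)n3)cc2)CC1)[C@H]1CCc2nc(N)sc2C1`: 2 nM

In an assay on brain for displacement of a labelled ligand from D(3) dopamine receptor (Rattus norvegicus) (a lower number here means a stronger inhibitor, a higher number a weaker inhibitor), compound 1 gives 2.4 nM, and compound 2 gives 2 nM. Within the data shown here, the one measured step, a 1.2-fold lower number from compound 1 to compound 2 (0.08 log units; within the scatter), does not separate the two, so compound 2 stands level with compound 1 on these numbers.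

Compound 3 `CCCN(CC[C@H]1CC[C@H](NC(=O)c2ccc(-c3noc(C4CC4)n3)cc2)CC1)[C@H]1CCc2nc(N)sc2C1` is not yet measured. Its difference from compound 2 is cyclopropyl in place of isopropyl on an aromatic carbon. Among the measured compounds shown here, no measured step touches this position alone; the single step known exchanges the whole five-membered group and stays within the scatter. A change of this size at the same place is therefore expected to give no step beyond the scatter in this assay, that is a 1.1-fold higher number from compound 2 to compound 3 (0.04 log units; within the scatter). Compound 3 is estimated at 2.2 nM, range 1 nM to 5 nM.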

Compound 3, inhibition constant: 3.5 nM
Beside the measured number, compound 3's estimate is 1.6-fold (0.20 log units) below it, within the range that was stated.
By their numbers in this assay, from the lowest: compounds 2, 1 and 3 (each within the scatter of the next).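

In this assay, the step confined to the aromatic carbon next to the ring oxygen (a 1.8-fold higher number from compound 2 to compound 3 (0.24 log units; within the scatter)) shows that cyclopropyl and isopropyl are not separated at this place. The exchange of the whole group (a 1.5-fold higher number from compound 1 to compound 3 (0.16 log units; within the scatter)) likewise leaves 5-cyclopropyl-1,2,4-oxadiazol-3-yl and 1H-1,2,4-triazol-1-yl unseparated. No available evidence bears on these results.

Open, on these data alone, is whether an amine, a carboxylic acid or a longer chain on this carbon would give a step beyond the scatter.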